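Replacing the propylcarbonyl group on the shared core

A few compounds are considered here, and "the series" means these few. Any claim that something is new, unique, unknown or untested is made for them only; others in the source may bear on it.

Measured in a functional assay for inhibition of nuclear factor NF-kappa-B complex (Homo sapiens); a higher number here means a weaker inhibitor, a lower number a stronger inhibitor:
compound 1, `COc1ccc2c(c1)OC(c1cc(OC)c(OC)c(OC)c1)C(C(=O)N1CCCCC1)=C2`: > 50000 nM, a limit of the assay and not a number
compound 2, `COc1ccc2c(c1)OC(c1cc(OC)c(OC)c(OC)c1)C(C(=O)Nc1ccccc1)=C2`: 17500 nM
compound 3, `CCCC(=O)C1=Cc2ccc(OC)cc2OC1c1cc(OC)c(OC)c(OC)c1`: 11700 nM

Compound 3 gives the lower of the two numbers shown, but its nearest neighbour is compound 2, and the step of a 1.5-fold lower number from compound 2 to compound 3 (0.17 log units; within the scatter) lies within the scatter, so the two cannot be ordered. Compound 1 stands at a limit (the limit of > 50000 nM in this assay, at which 1 of the 3 values shown sits). The steps of an at least 2.8-fold lower number from compound 1 to compound 2 (0.45 log units; beyond the scatter) and an at least 4.2-fold lower number from compound 1 to compound 3 (0.63 log units; beyond the scatter) are both beyond the scatter.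

Compound 4, `COc1ccc2c(c1)OC(c1cc(OC)c(OC)c(OC)c1)C(/C=N/O)=C2`, is not yet measured in this assay. The change from compound 3 is this: a group of 3 heavy atoms (1 carbon, 1 nitrogen, 1 oxygen; no ring) in place of a group of 5 heavy atoms (4 carbon, 1 oxygen; no ring), on a double-bonded ring carbon. The three measured steps all exchange the group on the carbonyl carbon while keeping the carbonyl itself; the step from compound 3 to compound 4 removes that carbonyl, so they bear on it only loosely. Exchanging anilino for propyl gave a 1.5-fold lower number from compound 2 to compound 3 (0.17 log units; within the scatter), within the scatter; only the piperidin-1-yl compound 1 stood apart. A step of modest size with no firm direction is therefore expected in this assay, estimated as a 1.3-fold higher number from compound 3 to compound 4 (0.11 log units; within the scatter). Compound 4 is estimated at 15000 nM, between 5000 nM and 50000 nM.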

Compound 4, half-maximal inhibitory concentration: 14100 nM
Compound 4: the middle estimate sits 1.1-fold (0.03 log units) above what was measured, within the range that was stated.
By their numbers in this assay, from the lowest: compounds 3, 4 and 2 (each within the scatter of the next). At a limit, above all of these: compound 1.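

In this assay, the carbonyl at this position, on a double-bonded ring carbon, can be exchanged without a readable change: the step shows a 1.2-fold higher number from compound 3 to compound 4 (0.08 log units; within the scatter), and against the anilino amide it shows a 1.2-fold lower number from compound 2 to compound 4 (0.09 log units; within the scatter). The entering group has no carbonyl, has fewer heavy atoms than propylcarbonyl and carries a hydrogen-bond donor that propylcarbonyl lacks, yet none of these differences separates compound 2, compound 3 and compound 4 in this assay. Compound 1 alone still stands apart, with an at least 3.5-fold lower number from compound 1 to compound 4 (0.54 log units; beyond the scatter), and the size of that step is open-ended, since the value of compound 1 is a limit of the assay and not a number: the limit of > 50000 nM in this assay, at which 1 of the 4 values shown sits.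

The compounds shown do not tell whether any group at this position can give a number clearly lower than those of compound 2, compound 3 and compound 4, which all lie within the scatter of one another. Going by these compounds, a carboxylic acid, a primary amine or a longer chain in place of propylcarbonyl remains open, as does the true number of compound 1.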